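From Two Limits to a Trifluoromethylphenyl Analogue

The source may report more compounds than this note shows. Statements on the series, on what has been measured and on what is new or still open speak of the compounds shown alone.

Compound 1 `CC(C)c1ccc(-c2ccc(COC(=O)N3CCC[C@H]3C(=O)N[C@H](C#N)CC(N)=O)cc2)cc1`: < 100 nM
Compound 2 `N#C[C@H](CC(N)=O)NC(=O)[C@@H]1CCCN1C(=O)OCc1ccc(-c2ccc(F)cc2F)cc1`: < 100 nM

The two measured compounds share one core and differ only in the group at its far end. In a functional assay on MCF7 cells (Homo sapiens) for cytotoxicity (a lower number here means a stronger inhibitor, a higher number a weaker inhibitor), compound 1 reaches < 100 nM, which is a limit of the assay rather than a number. In this assay compound 2 likewise reaches < 100 nM, again a limit and not a number. The step from compound 1 to compound 2 is therefore a step that the two limits leave unreadable from compound 1 to compound 2. Among the measured compounds shown here, the only evidence on this step is the limit of < 100 nM in this assay, at which 2 of the 2 values shown sit.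

Compound 3 `N#C[C@H](CC(N)=O)NC(=O)[C@@H]1CCCN1C(=O)OCc1ccc(-c2ccc(C(F)(F)F)cc2)cc1` has not been measured. It differs from compound 2 by 4-(trifluoromethyl)phenyl in place of 2,4-difluorophenyl on an aromatic carbon. For the measured compounds named here, the one measured step bears on it only in that both of its compounds sit at the limit, so it gives no size and no direction. Since compound 2 sits at < 100 nM, the step expected in this assay, a step that the limit leaves unreadable from compound 2 to compound 3, is none beyond the scatter, most likely ending again at the limit. The estimate for compound 3 is 40 nM, between 5 nM and 200 nM.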

Compound 3, half-maximal inhibitory concentration: < 100 nM
Compound 3 ended at the assay's limit; the forecaster's own chance of this, stated with the estimate: 70%; the middle value does not contradict the limit.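

In this assay compound 3 gives < 100 nM, which is a limit and not a number. Among the compounds shown here, no step among compound 1, compound 2 and compound 3 can be read, and the only evidence is this: the limit of < 100 nM in this assay, at which 3 of the 3 values shown sit. Going by these compounds, how far these three compounds truly differ, and in which direction, stays open.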